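The compounds below may be only part of what the source reports. "The series", "measured", "known", "first", "only" and "open" are said of these compounds alone.

Measured so far in a functional assay for inhibition, tested at 20 ug/mL; on this read-out higher numbers stand for a stronger effect at the one concentration tested and lower numbers for a weaker effect:
compound 1 `Cc1cc(O)c(C(C)C)cc1-c1cc(-c2ccccc2[N+](=O)[O-])c(C#N)c(=O)[nH]1` gives 20%
compound 2 `COc1cc(OC)c(-c2cc(-c3cc(C(C)C)c(O)cc3C)[nH]c(=O)c2C#N)c(OC)c1` gives 32%
compound 3 `Cc1cc(O)c(C(C)C)cc1-c1cc(-c2ccccc2Cl)c(C#N)c(=O)[nH]1` gives 12%

Compound 3 holds the lowest of the three numbers, though its gap to compound 1 is within the scatter; only compound 2 stands beyond it. Within the data shown here, the one step between neighbours that differ in a single place, a number 8 percentage points lower from compound 1 to compound 3 (within the scatter), concerns the same position as the change now at hand and is within the scatter, so it offers no guidance on methoxy substitution. Among the measured compounds shown here, no step is recorded between compound 2 and compound 3; their two values show only that the trimethoxyphenyl compound sits higher than the chlorophenyl one.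

The next compound, compound 4 `COc1ccc(-c2cc(-c3cc(C(C)C)c(O)cc3C)[nH]c(=O)c2C#N)c(OC)c1`, is not yet measured. It differs from compound 3 by 2,4-dimethoxyphenyl in place of 2-chlorophenyl on an aromatic carbon. For the measured compounds named here, the entering group resembles the aryl of compound 2, whose 32% is the only number bearing on methoxy groups at this position. A moderate rise is therefore expected, short of the value of compound 2 given the uncertainty. The expected step is a number 13 percentage points higher from compound 3 to compound 4 (beyond the scatter). Compound 4 is estimated at 25%, within 10% to 40%.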

Compound 4, a percentage reported as inhibition, at one concentration (the size of the read-out at that concentration, not a potency): 27%
The estimate for compound 4 lay 2 percentage points below the measured number, within the range that was stated.
By their numbers in this assay, from the lowest: compounds 3, 1, 4 and 2 (each within the scatter of the next, the first and the last beyond it).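

In this assay, among these compounds, 2,4-dimethoxyphenyl in place of 2-chlorophenyl gives a number 15 percentage points higher from compound 3 to compound 4 (beyond the scatter) and is the first change at this position with a step beyond the scatter. Hydrogen in place of one methoxy of the trimethoxyphenyl group gives a number 5 percentage points lower from compound 2 to compound 4 (within the scatter), so the third methoxy group has no effect that can be told from the scatter. The exchange of 2-nitrophenyl for 2,4-dimethoxyphenyl gives a number 7 percentage points higher from compound 1 to compound 4 (within the scatter), so these two aryl groups cannot be separated, and the series holds no measurement that accounts for any of these steps.

From the compounds shown here alone, whether both methoxy groups of the 2,4-dimethoxyphenyl group are needed remains open, as does the reading of a plain phenyl or a 4-methoxyphenyl group. Also open, going by these compounds, is how an aminophenyl or a carboxyphenyl group would read at this position.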